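The compounds below may be only part of what the source reports. "The series", "measured", "known", "first", "only" and "open" are said of these compounds alone.

Working notes on the series. Among the measured compounds shown here, in a functional assay on HCT-116 cells (Homo sapiens) for antiproliferative activity, read by MTT assay, with a stated time of 72 h (a lower number here means a stronger inhibitor, a higher number a weaker inhibitor), compound 1 `COc1ccc(/C=C2/CN(C)/C(=N/c3ccc(OC)cc3)S2)cc1` gives 15900 nM, the only true number available so far. Compound 2 `COc1ccc(/C=C2\S/C(=N\c3cc(C(F)(F)F)cc(C(F)(F)F)c3)N(C)C2=O)cc1` gives > 100000 nM in this assay, and this is a limit of the assay, not a number. Compound 1 therefore cannot be ranked against a second measured value.

The next compound to be read is compound 3 `COc1ccc(/C=C2/CN(C)/C(=N/c3ccc(Cl)cc3)S2)cc1`. It keeps the core of compound 1 and carries chloro in place of methoxy on an aromatic carbon, para to a large group, the change from 4-methoxyphenyl to 4-chlorophenyl: chloro in place of methoxy on an aromatic carbon.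

For the measured compounds named here, no measured pair shows the size of this exchange, so the data offer no direction for it. The expectation in this assay is a step no larger than the usual scatter, with a wide margin on either side. Going by the values given here, the only anchor is compound 1 at 15900 nM. The expected 1.1-fold lower number from compound 1 to compound 3 (0.06 log units; within the scatter) is accordingly small. For compound 3 the estimate is 14000 nM, with an expected range of 4500 nM to 45000 nM.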

Compound 3, half-maximal inhibitory concentration: 9800 nM
Estimate against measurement, compound 3: 1.4-fold (0.15 log units) above; measured number inside the range.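

In this assay, among the compounds shown here, the exchange of 4-methoxyphenyl for 4-chlorophenyl gives the first readable step: a 1.6-fold lower number from compound 1 to compound 3 (0.21 log units; within the scatter). At this place, para to a large group, the methoxy group with its counted hydrogen-bond acceptor leaves and chloro enters, with no step beyond the scatter, so this single pair shows that this exchange leaves the read-out within repeat variation on the core of compound 1. Compound 2 adds nothing to this reading, since its value is a limit of the assay and not a number: the limit of > 100000 nM in this assay, at which 1 of the 3 values shown sits.

Going by these compounds, one pair within the scatter gives no direction for this place, and it remains open whether an amine, a carboxylic acid or a longer alkoxy chain here would give a step beyond the scatter. Also open, on these data alone, is whether the same chloro for methoxy exchange on the other methoxy-bearing aromatic ring of compound 1 would read the same way in this assay.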